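Working notes: the step from compound 3 to compound 4

The source may report more compounds than this note shows. Statements on the series, on what has been measured and on what is new or still open speak of the compounds shown alone.

Measured compounds:
Compound 1, `Cc1ccc(-c2cn(C/C=C3\OC(=O)C(OCc4ccccc4)=C3OCc3ccccc3)nn2)cc1`: in a functional assay on MCF7 cells (Homo sapiens) for antiproliferative activity, read by MTT assay, with a stated time of 72 h (on this read-out lower numbers stand for stronger inhibition and higher numbers for weaker inhibition), compound 1 sits at a limit, > 100000 nM.
Compound 2, `O=C1O/C(=C\Cn2cc(-c3cc(F)cc(F)c3)nn2)C(OCc2ccccc2)=C1OCc1ccccc1`: in this assay compound 2 also sits at a limit, > 100000 nM.
Compound 3, `CCCCc1cn(C[C@H](O)[C@H]2OC(=O)C(OCc3ccccc3)=C2OCc2ccccc2)nn1`: in this assay compound 3 gives 7910 nM.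

Going by the values given here, compound 3 carries the only number in the set; the other two values are limits, as noted in the limit of > 100000 nM in this assay, at which 2 of the 3 values shown sit. Among the compounds with values here, the one single-point step, a step that the two limits leave unreadable from compound 1 to compound 2, cannot be read because both ends are limits, so no measured step gives a size to carry forward.

The unmeasured compound 4, `O=C1O[C@H]([C@@H](O)Cn2cc(CNS(=O)(=O)c3ccc(Cl)cc3)nn2)C(OCc2ccccc2)=C1OCc1ccccc1`, differs from compound 3 by ((4-chlorophenyl)sulfonyl)amino in place of propyl on a saturated chain carbon bound to an aromatic carbon. Within the data shown here, nothing measured bears on this change: the only step is unreadable, and no other pair differs in one place. The expectation therefore rests on compound 3 alone, with wide bounds. Compound 4 is estimated at 7000 nM, with a range from 1500 nM to 35000 nM. The expected step is a 1.1-fold lower number from compound 3 to compound 4 (0.05 log units; within the scatter), that is, no change beyond the scatter.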

Compound 4, half-maximal inhibitory concentration: 4170 nM
Compound 4: middle estimate off by 1.7-fold (0.22 log units), on the high side, and the stated range covers the measured number.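

In this assay, ((4-chlorophenyl)sulfonyl)amino in place of propyl on a saturated chain carbon bound to an aromatic carbon gives a 1.9-fold lower number from compound 3 to compound 4 (0.28 log units; within the scatter), so this place in the series tolerates 11 heavy atoms and an aromatic ring instead of 3 heavy atoms and no ring, with no change beyond the scatter. Going by these compounds alone, this is the first step that can be read, as the step from compound 1 to compound 2 cannot be read. Nothing shown accounts for the two numbers standing within the scatter of each other.

From the compounds shown here alone, whether an amine, a carboxylic acid or a longer chain at this place would move the number beyond the scatter stays open. Also open, going by these compounds, is whether the chlorine matters, which an unsubstituted phenyl ring on the sulfonyl would test.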